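This account rests on a few compounds, and the source may have more. Where it says the series, first, only, none or still open, it means among the compounds named here.

Three compounds have been measured in an assay for inhibition of methylcytosine dioxygenase TET2 (Homo sapiens), read by mass spectrometry, with stated times of 30 min and 1 h; on this read-out higher numbers stand for weaker inhibition and lower numbers for stronger inhibition:

Compound 1 `Cc1oncc1NS(=O)(=O)c1ccc(F)c2ncc(I)cc12` gives 2100 nM.
Compound 2 `O=S(=O)(O)c1ccc(F)c2ncc(I)cc12` gives 2300 nM.
Compound 3 `CCCCCOS(=O)(=O)c1ccc(F)c2ncc(I)cc12` gives only a limit of this assay, > 200000 nM.

Compound 2 stands at the highest of the two plain numbers, with compound 1 nearest: the step of a 1.1-fold higher number from compound 1 to compound 2 (0.04 log units; within the scatter) lies within the scatter, so the two cannot be told apart. Compound 3 sits at the limit (the limit of > 200000 nM in this assay, at which 1 of the 3 values shown sits), and the step of an at least 86-fold higher number from compound 2 to compound 3 (1.93 log units; beyond the scatter) is large.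

Compound 4 `CNS(=O)(=O)c1ccc(F)c2ncc(I)cc12` is the unmeasured one. It differs from compound 2 in this way: methylamino in place of hydroxy on a sulfonyl sulfur. Going by the values given here, two measured steps bear on this. Replacing the hydroxy on the sulfonyl sulfur by a pentyl ester, in compound 3, gave a large loss. Replacing it by a nitrogen carrying a five-membered aromatic ring, in compound 1, gave no change beyond the scatter. Compound 4 carries a nitrogen on the sulfonyl sulfur like compound 1, so the expected step of a 1.1-fold higher number from compound 2 to compound 4 (0.04 log units; within the scatter) is no change beyond the scatter. Compound 4 is therefore estimated at 2500 nM, between 1000 nM and 8000 nM.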

Compound 4, half-maximal inhibitory concentration: > 200000 nM
Compound 4: a limit, no number; the forecaster's own chance of this, stated with the estimate: 5%; middle value at least 80-fold (1.90 log units) away from the limit.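

On the sulfonyl sulfur, having a nitrogen is not enough to keep inhibition in this assay: methylamino in place of hydroxy gives an at least 86-fold higher number from compound 2 to compound 4 (1.93 log units; beyond the scatter), and methyl in place of 5-methyl-1,2-oxazol-4-yl on the sulfonamide nitrogen gives an at least 95-fold higher number from compound 1 to compound 4 (1.97 log units; beyond the scatter). What the sulfonamide nitrogen carries therefore matters a great deal here, which compound 1 and compound 2 could not show, as their values lie within the scatter of each other. The value of compound 4 is a limit and not a number, and the step between compound 3 and compound 4 cannot be read, as both sit at it: the limit of > 200000 nM in this assay, at which 2 of the 4 values shown sit.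

The compounds shown leave open whether a phenyl group or a longer chain on the sulfonamide nitrogen would restore inhibition. They also leave open how a carboxylic acid in place of the sulfo group would read out.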